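Moving the fluorine on the phenyl ring of compound 3

A few compounds are considered here, and "the series" means these few. Any claim that something is new, unique, unknown or untested is made for them only; others in the source may bear on it.

Measured so far:
compound 1, `O=C1CSC(c2cccc(O)c2)N1CCN1CCCCC1`: 100%
compound 2, `Cc1ccc(C2SCC(=O)N2CCN2CCCCC2)cc1`: 51%
compound 3, `O=C1CSC(c2ccc(F)cc2)N1CCN1CCCCC1`: 52%

In an ADME assay on Vero cells (Chlorocebus sabaeus) for cytotoxicity, read by neutral red uptake, tested at 394 ug/mL (on this read-out lower numbers stand for a stronger effect and higher numbers for a weaker effect at the one concentration tested), compound 3 gives 52%, the second highest of the three numbers. Its nearest neighbour is compound 2, with a number 1 percentage points higher from compound 2 to compound 3 (within the scatter); the furthest is compound 1, with a number 48 percentage points lower from compound 1 to compound 3 (beyond the scatter). Compound 2 and compound 3 thus sit together, while compound 1 stands apart.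

Compound 4, `O=C1CSC(c2cccc(F)c2)N1CCN1CCCCC1`, has not been measured. It differs from compound 3 in one place: 3-fluorophenyl in place of 4-fluorophenyl on a saturated ring carbon.

Within the data shown here, none of the measured steps moves the fluorine from one ring carbon to another. The steps that reach compound 3 either exchange the whole aryl group, as in a number 48 percentage points lower from compound 1 to compound 3 (beyond the scatter), or swap the substituent at the same position, as in a number 1 percentage points higher from compound 2 to compound 3 (within the scatter), which stays within the scatter. Among the measured compounds shown here, the only large steps seen, a number 49 percentage points lower from compound 1 to compound 2 (beyond the scatter) and a number 48 percentage points lower from compound 1 to compound 3 (beyond the scatter), both involve replacing the 3-hydroxyphenyl of compound 1, which is not at stake here. Keeping the same atoms and only rearranging the fluorine is therefore expected to give no step beyond the scatter, though the evidence is thin. For compound 4 the expected step is a number 5 percentage points higher from compound 3 to compound 4 (within the scatter), and its estimated value in this assay is 57%, within a range from 35% to 90%.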

Compound 4, a percentage reported as activity, at one concentration (the size of the read-out at that concentration, not a potency): 60%
Compound 4: middle estimate off by 3 percentage points, on the low side; low and high end bracket the measured number.
By their numbers in this assay, from the lowest: compounds 2, 3 and 4 (each within the scatter of the next); then compound 1.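

In this assay, moving the fluorine gives a number 8 percentage points higher from compound 3 to compound 4 (within the scatter), so for this pair the change from 4-fluorophenyl to 3-fluorophenyl on the saturated ring carbon has no effect that can be told from scatter, and exchanging the 4-methylphenyl for the 3-fluorophenyl, a number 9 percentage points higher from compound 2 to compound 4 (within the scatter), likewise stays within it. Among these compounds, compound 4 also supplies what the earlier compounds could not: a comparison with compound 1 in which the aryl substituent keeps its ring position and only fluoro takes the place of hydroxy on the aromatic carbon, and this gives a number 40 percentage points lower from compound 1 to compound 4 (beyond the scatter), so the large gap to compound 1 does not depend on a shift of the substituent around the ring. Nothing measured here accounts for either result.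

On these data alone, what stays open is whether the high number of compound 1 goes with a hydroxy group wherever it stands on the phenyl ring, a question that a 4-hydroxyphenyl on the same carbon would address. As far as these compounds go, it is also open whether a 3-methoxyphenyl or a 3-aminophenyl would fall with compound 1 or with compound 2, compound 3 and compound 4.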